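From Ethoxy to Isopropoxy: Expecting a Modest Loss

A few compounds are considered here, and "the series" means these few. Any claim that something is new, unique, unknown or untested is made for them only; others in the source may bear on it.

Of the compounds shown here, three on a shared core have been measured. Compound 1 `CCO[C@@]1(c2ccc(Cl)cc2)SC=C(C)n2c1noc2=O` gives in a functional assay (Cavia porcellus) with Rattus norvegicus as the target (on this read-out lower numbers stand for an effect already at smaller amounts and higher numbers for an effect only at larger amounts of compound), 270 nM; compound 2 `CCCOC1(c2ccc(Cl)cc2)SC=C(C)n2c1noc2=O` gives 890 nM; compound 3 `CCCCOC1(c2ccc(Cl)cc2)SC=C(C)n2c1noc2=O` gives 1850 nM. The step of a 2.1-fold higher number from compound 2 to compound 3 (0.32 log units; beyond the scatter) arises from methyl in place of hydrogen on a saturated chain carbon, three bonds along the chain from an oxygen on a saturated carbon. How the core of compound 1 differs from that of compound 2 is not broken down here. Compound 1 gives the lowest of the three numbers.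

Compound 4 `CC1=CS[C@@](OC(C)C)(c2ccc(Cl)cc2)c2noc(=O)n21` has not yet been measured in this assay; it differs from compound 1 by methyl in place of hydrogen on a saturated chain carbon bound to an oxygen on a saturated carbon and a saturated chain carbon. This is the same kind of change as between compound 2 and compound 3, but the place differs: there the methyl enters three bonds along the chain from an oxygen on a saturated carbon, here on a carbon bound to that oxygen and a saturated chain carbon. Because methyl for hydrogen gave a 2.1-fold higher number from compound 2 to compound 3 (0.32 log units; beyond the scatter), for compound 4 a step of a 1.9-fold higher number from compound 1 to compound 4 (0.27 log units; within the scatter) is expected. Compound 4 is estimated at 500 nM, between 250 nM and 1200 nM.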

Compound 4, half-maximal effective concentration: 220 nM
Compound 4: middle estimate off by 2.3-fold (0.36 log units), on the high side, outside the stated range (below it).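

In this assay the change from ethoxy to isopropoxy gives a 1.2-fold lower number from compound 1 to compound 4 (0.09 log units; within the scatter) and so does not separate the two compounds. Set beside the earlier methyl-for-hydrogen step, the results on the two cores cannot be told apart: the same change on two cores in this assay, a 2.1-fold higher number (0.32 log units; beyond the scatter) from compound 2 to compound 3 and a 1.2-fold lower number (0.09 log units; within the scatter) from compound 1 to compound 4, 2.6-fold (0.41 log units) apart, within the scatter of two such steps. Among these compounds, this gives no sign that the core alters the outcome, but it does not show that the change carries over, since each core offers only one step and the methyl sits at a different place in each.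

The compounds shown leave open whether a tert-butoxy group or a longer chain in place of the ethoxy would match compound 1. They also leave open how an amine there would read.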